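The source may report more compounds than this note shows. Statements on the series, on what has been measured and on what is new or still open speak of the compounds shown alone.

Of the compounds shown here, two built on the shared core have been measured. In a functional assay on MGC-803 cells (Homo sapiens) for antiproliferative activity, read by CCK-8 assay, with a stated time of 72 h, tested at 8 uM (a higher number here means a stronger effect of the compound at the concentration tested, a lower number a weaker effect), compound 1 `CC1CCN(C(=S)SCc2ccc(C(=O)Nc3ccccc3N)cc2)CC1` gives 81.9%, and compound 2 `Nc1ccccc1NC(=O)c1ccc(CSC(=S)N2CCN(c3ccccc3F)CC2)cc1` gives 86.4%. Compound 2 holds the higher of the two numbers, yet its gap to compound 1 lies within the scatter, so neither can be called the stronger. Compound 3 `CN1CCN(C(=S)SCc2ccc(C(=O)Nc3ccccc3N)cc2)CC1` has not been measured; it differs from compound 2 by methyl in place of 2-fluorophenyl on an amine nitrogen in a ring. Among the compounds with values here, no step between measured compounds covers such a change, so its size is open. The change is expected to bring a modest fall, a number 16.4 percentage points lower from compound 2 to compound 3 (beyond the scatter) in this assay. Compound 3 is therefore estimated at 70%, between 50% and 88%.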

Compound 3, a percentage reported as inhibition, at one concentration (the size of the read-out at that concentration, not a potency): 84.4%
The estimate for compound 3 lay 14.4 percentage points below the measured number; the measured number falls inside the stated range.
By their numbers in this assay, from the lowest: compounds 1, 3 and 2 (each within the scatter of the next).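

In this assay, the ring nitrogen accepts methyl in place of 2-fluorophenyl without a change beyond the scatter (a number 2 percentage points lower from compound 2 to compound 3 (within the scatter)), so the aromatic ring is not required for this read-out at this concentration. Replacing 4-methylpiperidin-1-yl with 4-methylpiperazin-1-yl on the thiocarbonyl carbon likewise leaves the number within the scatter (a number 2.5 percentage points higher from compound 1 to compound 3 (within the scatter)). Nothing at hand explains this result. Going by these compounds, it remains open whether a carboxylic acid or a longer chain on this ring nitrogen would shift the number. On these data alone, whether these compounds would separate at lower concentrations also remains open.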